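Two More Chain Carbons and Toxicity Toward Cultured Cells

The compounds below may be only part of what the source reports. "The series", "measured", "known", "first", "only" and "open" are said of these compounds alone.

compound 1 `CCCCCCNc1cncc(C(=O)NCc2ccccc2)n1`: > 100000 nM
compound 2 `O=C(NCc1ccccc1)c1cnc(Cl)cn1`: "not determined" (no result reported)
compound 3 `CCCCCCCCNc1cncc(C(=O)NCc2ccccc2)n1`: to be measured

In an ADME assay on HeLa cells (Homo sapiens) for cytotoxicity, read by microscopy, with a stated time of 6 days (on this read-out higher numbers stand for lower toxicity in this test and lower numbers for higher toxicity in this test), compound 1 gives > 100000 nM, which is a limit of the assay and not a number. Compound 1 therefore stands at the limit of > 100000 nM in this assay, at which 1 of the 2 values shown sits. Compound 2 has no result in this assay, recorded as "not determined" (no result reported). Compound 3 differs from compound 1 by ethyl in place of hydrogen on a saturated chain carbon, six bonds along the chain from a nitrogen on an aromatic ring. Within the data shown here, with no measured step to rest on, the change is expected to be small, a number no higher from compound 1 to compound 3 (the limit leaves the size open), not beyond the usual scatter. Compound 3 is accordingly estimated at 100000 nM, with a range from 30000 nM to 300000 nM.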

Compound 3, minimum cytotoxic concentration: > 100000 nM
Compound 3: no number, only a limit (the forecaster's own chance of this, stated with the estimate: 60%); the middle value lies on the limit itself.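

In this assay, compound 1 and compound 3 each give only a limit, not a number, so the step between them cannot be read: the limit of > 100000 nM in this assay, at which 2 of the 3 values shown sit.

The compounds shown leave open whether adding ethyl to the chain changes toxicity at all.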